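The source may hold more compounds than are shown below. What is called first, only, known or untested is meant among the compounds shown, and "the series" means these compounds.

The compounds measured so far in an ADME assay on 184B5 cells (Homo sapiens) for cytotoxicity, read by sulforhodamine B assay, with a stated time of 48 h; on this read-out higher numbers stand for weaker inhibition of growth and lower numbers for stronger inhibition of growth:

compound 1, `CCN(CC)CN1C(=O)/C(=N\c2nc3ccc(C)cc3s2)c2ccccc21`, giving 27500 nM
compound 2, `Cc1ccc2nc(/N=C3\C(=O)N(CN4CCCCC4)c4ccccc43)sc2c1`, giving 34900 nM
compound 3, `O=C1C(=O)N(CN2CCCCC2)c2cccc(Cl)c21`, giving 93700 nM

Compound 3 stands highest of the three numbers, and its gap to each of the other two lies beyond the scatter of repeated measurements. Compound 1 and compound 2 lie within the scatter of each other, so no order between them is claimed. The difference between the core of compound 2 and the core of compound 3 is not broken down here.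

Compound 4, `CCN(CC)CN1C(=O)C(=O)c2c(Cl)cccc21`, has not yet been measured in this assay. It differs from compound 3 by diethylamino in place of piperidin-1-yl on a saturated chain carbon bound to an amide-type nitrogen in a ring. The same change, (diethylamino in place of piperidin-1-yl on a saturated chain carbon bound to an amide-type nitrogen in a ring), links compound 2 and compound 1, and there it made a 1.3-fold lower number from compound 2 to compound 1 (0.10 log units; within the scatter). The place of the change is the same in both pairs, so it is the same change, seen twice among these compounds, and nothing in the data suggests it should act differently on the core of compound 3.

For compound 4 the expected step is a 1.2-fold lower number from compound 3 to compound 4 (0.10 log units; within the scatter) because the earlier occurrence gave a 1.3-fold lower number from compound 2 to compound 1 (0.10 log units; within the scatter). Compound 4 is therefore estimated at 75000 nM, within a range of 35000 nM to 160000 nM.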

Compound 4, concentration for 50% growth inhibition: 22500 nM
Estimate against measurement, compound 4: 3.3-fold (0.52 log units) above, outside the stated range (below it).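

In this assay, putting diethylamino in place of piperidin-1-yl on the saturated chain carbon bound to the amide-type nitrogen in a ring gives a 4.2-fold lower number from compound 3 to compound 4 (0.62 log units; beyond the scatter), a change that counts on this core. Set beside its earlier occurrence, the same change does not carry over in size from one core to the other: the same change on two cores in this assay, a 1.3-fold lower number (0.10 log units; within the scatter) from compound 2 to compound 1 and a 4.2-fold lower number (0.62 log units; beyond the scatter) from compound 3 to compound 4, 3.3-fold (0.52 log units) apart, beyond the scatter of two such steps

This shows that, in this series, the size of the step on one core cannot simply be transferred to another, although the place of the change is the same in both pairs; it does not show what sets the two cores apart, and two pairs give no rule for any further core.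

From the compounds shown here alone, it remains open whether another amine on the same chain carbon, such as morpholin-4-yl or dimethylamino, would follow the larger step or the smaller one. Going by these compounds, it is also open whether the core of compound 3 with bromo in place of chloro would keep the larger step.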